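Trading Arginine-like Side Chain for Leucine-like Isopropyl

A few compounds are considered here, and "the series" means these few. Any claim that something is new, unique, unknown or untested is made for them only; others in the source may bear on it.

In a functional assay on the whole organism (Tail, strain ICR) with Mus musculus as the target, in the tail flick test, with a stated time of 30 min, at a dose of 25 umol/kg by the oral route (on this read-out lower numbers stand for a weaker effect and higher numbers for a stronger effect at the one dose given), three compounds sharing one core have been measured. Compound 1 `O=C(O)C[C@H](NC(=O)CN(c1nc(Cl)nc2[nH]cnc12)C1CC1)C(=O)O` gives 19.9%, compound 2 `NC(=O)CC[C@H](NC(=O)CN(c1nc(Cl)nc2[nH]cnc12)C1CC1)C(=O)O` gives 33.1%, and compound 3 `N=C(N)NCCC[C@H](NC(=O)CN(c1nc(Cl)nc2[nH]cnc12)C1CC1)C(=O)O` gives 45.4%, the highest of the three, with compound 2 nearest and compound 1 furthest from it. The steps run upward along this series: a number 13.2 percentage points higher from compound 1 to compound 2 (beyond the scatter), a number 12.3 percentage points higher from compound 2 to compound 3 (beyond the scatter), and a number 25.5 percentage points higher from compound 1 to compound 3 (beyond the scatter).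

Compound 4 `CC(C)C[C@H](NC(=O)CN(c1nc(Cl)nc2[nH]cnc12)C1CC1)C(=O)O` differs from compound 3 in one place: a group of 3 heavy atoms (3 carbon; no ring) in place of a group of 6 heavy atoms (3 carbon, 3 nitrogen; no ring), on a saturated chain carbon, two bonds along the chain from an amide-type nitrogen and a carbonyl carbon. Within the data shown here, each measured step brought in a group carrying nitrogen at this chain position; none of them introduces a group of carbon alone, so no step speaks directly to the change now made. The measured steps were all of modest size, and the three side chains differ in what they carry without any one of them resembling isopropyl. A modest step in either direction is therefore possible, and a downward step is expected as more likely, since every group that raised the activity contained nitrogen and the isopropyl contains none. Compound 4 is accordingly estimated at 30%, within a range from 10% to 55%, meaning an expected step of a number 15.4 percentage points lower from compound 3 to compound 4 (beyond the scatter).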

Compound 4, a percentage reported as activity, at one dose (the size of the read-out at that dose, not a potency): 23.4%
The estimate for compound 4 lay 6.6 percentage points above the measured number; low and high end bracket the measured number.
By their numbers in this assay, from the lowest: compounds 1, 4 and 2 (each within the scatter of the next, the first and the last beyond it); then compound 3.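

With a group of carbon alone on the saturated chain carbon, replacing the group of compound 3 gives a number 22 percentage points lower from compound 3 to compound 4 (beyond the scatter), so compound 3 now stands clear of all three other side chains in this assay. Isopropyl in place of the other two groups gives a number 9.7 percentage points lower from compound 2 to compound 4 (within the scatter) and a number 3.5 percentage points higher from compound 1 to compound 4 (within the scatter), so it cannot be told apart from either carbamoylmethyl or carboxy, even though those two differ from each other beyond the scatter. Nothing available here accounts for these differences.

As far as these compounds go, it remains open whether the level of compound 3 requires the whole group of 6 heavy atoms, or whether a simple primary amine on a chain of similar length would reach it. Also open, from the compounds shown here alone, is whether a longer carbon chain or a phenyl ring at this place would stay level with isopropyl.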